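Swapping bromo for nitro on an amide-linked phenyl

This account rests on a few compounds, and the source may have more. Where it says the series, first, only, none or still open, it means among the compounds named here.

Compound 3 `O=C(COc1ccc2c(=O)ccoc2c1)Nc1cccc(NC(=O)c2ccc(Br)cc2)c1` is the strongest of the three measured compounds in an assay on isolated protein for inhibition of Rho-associated protein kinase 1 (Homo sapiens), read by scintillation counting, radiometric assay and 33P incorporation, with a stated time of 40 min, in the presence of a further agent that is not named here; a lower number here means a stronger inhibitor, a higher number a weaker inhibitor: compound 3 gives 303 nM, while compound 1 `CC(=O)Nc1cccc(NC(=O)COc2ccc3c(=O)ccoc3c2)c1` gives 2500 nM and compound 2 `CCCC(=O)Nc1cccc(NC(=O)COc2ccc3c(=O)ccoc3c2)c1` gives 1430 nM. Both steps toward compound 3 lie beyond the scatter, an 8.3-fold lower number from compound 1 to compound 3 (0.92 log units; beyond the scatter) and a 4.7-fold lower number from compound 2 to compound 3 (0.67 log units; beyond the scatter), whereas a 1.7-fold lower number from compound 1 to compound 2 (0.24 log units; within the scatter). Compound 4 `O=C(COc1ccc2c(=O)ccoc2c1)Nc1cccc(NC(=O)c2ccc([N+](=O)[O-])cc2)c1` carries one change: nitro in place of bromo on an aromatic carbon. For the measured compounds named here, no measured step exchanges one group for another on that aromatic ring; the measured steps show only that 4-bromophenyl outperforms methyl and propyl. Without such a guide, the expected step is a 1.3-fold higher number from compound 3 to compound 4 (0.12 log units; within the scatter), not beyond the scatter. Compound 4 is therefore estimated at 400 nM, in the range 150 nM to 1200 nM in this assay.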

Compound 4, half-maximal inhibitory concentration: 67 nM
Compound 4: the middle estimate sits 6.0-fold (0.78 log units) above what was measured; measured number below the stated range.
By their numbers in this assay, from the lowest: compound 4; then compound 3; then compounds 2 and 1 (each within the scatter of the next).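

In this assay the group on this aromatic carbon itself counts, not only the presence of the ring: nitro in place of bromo gives a 4.5-fold lower number from compound 3 to compound 4 (0.66 log units; beyond the scatter) on an otherwise unchanged structure. The lead of the 4-nitrophenyl amide over the propyl and methyl amides reaches a 21-fold lower number from compound 2 to compound 4 (1.33 log units; beyond the scatter) and a 37-fold lower number from compound 1 to compound 4 (1.57 log units; beyond the scatter) in the same assay. Nothing available here explains why nitro gives the lower number.

On these data alone, whether an amine, a carboxylic acid or a methoxy group on this carbon would give a lower number remains open. So does whether nitro would keep its advantage elsewhere on the ring.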